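The source may hold more compounds than are shown below. What is called first, only, known or untested is meant among the compounds shown, and "the series" means these compounds.

Compound 1 `O=C(/C=C/c1ccccc1Cl)c1ccc(OCc2ccccc2)cc1` — 54.5%
Compound 2 `O=C(/C=C/c1ccc(OCc2ccccc2)cc1)c1ccccc1` — 52.3%

The two measured compounds share the same core, and both were tested in a functional assay on HCT-116 cells (Homo sapiens) for antiproliferative activity, read by sulforhodamine B assay, with a stated time of 3 days, tested at 25 uM; on this read-out higher numbers stand for a stronger effect at the one concentration tested and lower numbers for a weaker effect. In this assay compound 1 gives 54.5%, and compound 2 gives 52.3%. Compound 2 stands at the lower of the two numbers, but its value lies only a little below that of compound 1, and the gap between them falls within the scatter of repeated measurements, so the two are best read as equivalent.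

Compound 3 `O=C(/C=C/c1ccc(Cl)cc1)c1ccccc1` has not yet been measured in this assay. It differs from compound 2 in one place: chloro in place of benzyloxy on an aromatic carbon. For the measured compounds named here, no measured pair shows this change, so its effect cannot be read from the numbers at hand.

Going by the values given here, with no comparable step to lean on, the expected step from compound 2 to compound 3 is a number 12.3 percentage points lower from compound 2 to compound 3 (beyond the scatter), a modest decrease that may still fall within the scatter. On that basis compound 3 is estimated to give 40% in this assay, with a range from 15% to 65%.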

Compound 3, a percentage reported as inhibition, at one concentration (the size of the read-out at that concentration, not a potency): 97.5%
Beside the measured number, compound 3's estimate is 57.5 percentage points below it, outside the stated range (above it).
By their numbers in this assay, from the lowest: compounds 2 and 1 (each within the scatter of the next); then compound 3.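

In this assay, the exchange of benzyloxy for chloro on this aromatic carbon, para to a large group, comes with a number 45.2 percentage points higher from compound 2 to compound 3 (beyond the scatter), so the read-out responds strongly to what sits at this position, something compounds 1 and 2, whose numbers lie within the scatter of each other, could not show. The change removes benzyloxy with its aromatic ring and puts a single chlorine atom in its place, so within this pair benzyloxy is not required at this position for a strong effect at the one concentration tested. Nothing at hand gives a reason for the size of this step.

The compounds shown leave open whether the higher number of compound 3 goes with the loss of benzyloxy, with the arrival of chloro, or with both, as a single step cannot separate the two. They also leave open how a plain hydrogen, a methoxy group, an amine or a carboxylic acid on this carbon would read, and whether the difference at this one concentration would carry over to other concentrations.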